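A few compounds are considered here, and "the series" means these few. Any claim that something is new, unique, unknown or untested is made for them only; others in the source may bear on it.

Measured compounds: compound 1 `CC(C(=O)NCc1ccc(C(F)(F)F)nc1SCCOc1ccccc1)c1ccc(NS(C)(=O)=O)c(F)c1` with 2.3 nM, compound 2 `CC1CCN(CCCSc2nc(C(F)(F)F)ccc2CNC(=O)C(C)c2ccc(NS(C)(=O)=O)c(F)c2)CC1` with 2.9 nM, and compound 3 `CC(C(=O)NCc1ccc(C(F)(F)F)nc1SCCC(=O)N1CCCC1)c1ccc(NS(C)(=O)=O)c(F)c1` with 85 nM, all in an assay on CHO-K1 cells for antagonist activity at transient receptor potential cation channel subfamily V member 1 (Homo sapiens), read by FLIPR; on this read-out higher numbers stand for weaker inhibition and lower numbers for stronger inhibition.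

Compound 3 gives the highest of the three numbers; the next is compound 2, reached by a 29-fold higher number from compound 2 to compound 3 (1.47 log units; beyond the scatter), and the furthest is compound 1, reached by a 37-fold higher number from compound 1 to compound 3 (1.57 log units; beyond the scatter). Compound 4 `COc1ccc(CSc2nc(C(F)(F)F)ccc2CNC(=O)C(C)c2ccc(NS(C)(=O)=O)c(F)c2)cc1` differs from compound 3 in one place: 4-methoxyphenyl in place of ((pyrrolidin-1-yl)carbonyl)methyl on a saturated chain carbon bound to a sulfur. Both steps onto compound 3 bear on this, since each exchanges the pyrrolidinylcarbonyl-bearing chain for a group without that carbonyl and both are large, while compound 1 and compound 2 lie within the scatter of each other. A large drop in this assay is therefore expected for compound 4, a 21-fold lower number from compound 3 to compound 4 (1.33 log units; beyond the scatter), toward the range of compound 1. Compound 4 is estimated at 4 nM, between 1.5 nM and 15 nM.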

Compound 4, inhibition constant: 2.3 nM
For compound 4 the middle estimate is 1.7-fold (0.24 log units) above the measured one, and the stated range covers the measured number.
By their numbers in this assay, from the lowest: compounds 1, 4 and 2 (each within the scatter of the next); then compound 3.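

In this assay, 4-methoxyphenyl in place of ((pyrrolidin-1-yl)carbonyl)methyl on this carbon gives a 37-fold lower number from compound 3 to compound 4 (1.57 log units; beyond the scatter), so a benzyl-type group directly on the sulfur fits as well as the longer chains. Compound 4 stays within the scatter of both, with a 1.3-fold lower number from compound 2 to compound 4 (0.10 log units; within the scatter) and no change at the digits printed from compound 1 to compound 4 (within the scatter), leaving compound 3 alone apart among these four. Nothing given here explains why compound 3 differs. Open, as far as these compounds go, is whether the carbonyl or the pyrrolidine ring accounts for that gap. Also open, from the compounds shown here alone, is how a carboxylic acid or an unsubstituted benzyl group would read at this position.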